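The compounds below may be only part of what the source reports. "The series", "measured", "known", "first", "only" and "open" are said of these compounds alone.

Measured in a functional assay on MCF7 cells (Homo sapiens) for antiproliferative activity, read by MTT assay, with a stated time of 48 h; on this read-out lower numbers stand for stronger inhibition and higher numbers for weaker inhibition:

- compound 1 `CCn1c(C(=O)NCCCN(C)C)ccc1C(CC)(CC)c1ccc(OCCC(O)(CC)CC)c(C)c1`: 3350 nM
- compound 2 `CCn1c(C(=O)NCCN(C)C)ccc1C(CC)(CC)c1ccc(OCCC(O)(CC)CC)c(C)c1`: 430 nM
- compound 3 `CCn1c(C(=O)NCC#N)ccc1C(CC)(CC)c1ccc(OCCC(O)(CC)CC)c(C)c1`: > 50000 nM, a limit of the assay

Compound 2, at 430 nM, holds the lower of the two true numbers. The nearest number is that of compound 1, and the gap is a 7.8-fold lower number from compound 1 to compound 2 (0.89 log units; beyond the scatter). Compound 3 gives only a limit, > 50000 nM.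

Compound 4 `CCn1c(C(=O)N(CCC#N)CCC#N)ccc1C(CC)(CC)c1ccc(OCCC(O)(CC)CC)c(C)c1` has not yet been measured. It departs from compound 2 on a carbonyl carbon: a group of 9 heavy atoms (6 carbon, 3 nitrogen; no ring) in place of a group of 6 heavy atoms (4 carbon, 2 nitrogen; no ring), on a carbonyl carbon. The (2-(dimethylamino)ethyl)amino group leaves, and the entering group has no common name.

The closest guide is an at least 110-fold higher number from compound 2 to compound 3 (2.06 log units; beyond the scatter), a large step in which cyano also takes the place of (dimethylamino)methyl. The step of an at least 14-fold higher number from compound 1 to compound 3 (1.17 log units; beyond the scatter) is also large and points the same way. Among the compounds with values here, none of the measured compounds lacks the amide hydrogen, so that part of the change is untested. A large step towards higher numbers is therefore expected in this assay. The estimated change is a 58-fold higher number from compound 2 to compound 4 (1.76 log units; beyond the scatter). For compound 4 the expected value is 25000 nM, with an estimated range of 5000 nM to 50000 nM.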

Compound 4, half-maximal inhibitory concentration: > 50000 nM
Compound 4: a limit, no number; the forecaster's own chance of this, stated with the estimate: 45%; middle value at least 2.0-fold (0.30 log units) from the limit.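

In this assay compound 4 gives > 50000 nM, a limit of the assay and not a number. Placing the entering group, with 0 hydrogen-bond donors and 2 triple bonds outside aromatic rings, on the carbonyl carbon gives an at least 110-fold higher number from compound 2 to compound 4 (2.06 log units; beyond the scatter), and the comparison with the longer dimethylamino chain gives an at least 14-fold higher number from compound 1 to compound 4 (1.17 log units; beyond the scatter), so the high read-out first seen with the nitrile of compound 3 also appears on a carbonyl carbon whose amide nitrogen carries no hydrogen. Compound 3 and compound 4 sit at the same limit, so the step between them cannot be read: the limit of > 50000 nM in this assay, at which 2 of the 4 values shown sit.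

The compounds shown leave the two parts of this change unseparated: the loss of the amide hydrogen and the loss of the dimethylamino end. A methyl group on the amide nitrogen alongside the 2-(dimethylamino)ethyl chain would speak to the first part, and a morpholine or a carboxylic acid at the chain end would speak to the second.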